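Swapping trifluoromethyl for fluoro in a small series

This account rests on a few compounds, and the source may have more. Where it says the series, first, only, none or still open, it means among the compounds named here.

compound 1 `CC1(/C=C/c2ccccc2)C=CC(=O)O1`: 170000 nM
compound 2 `CC1(/C=C/c2ccccc2C(F)(F)F)C=CC(=O)O1`: 27900 nM
compound 3 `CC1(/C=C/c2ccc(C(F)(F)F)cc2)C=CC(=O)O1`: 34000 nM

In a functional assay on 786-0 cells (Homo sapiens) for inhibition, read by sulforhodamine B assay, with a stated time of 48 h (a lower number here means a stronger inhibitor of growth, a higher number a weaker inhibitor of growth), compound 1 has the highest number of the three. Compound 2 and compound 3 lie within the usual scatter of each other, and both lie clearly lower than compound 1.

The next compound is compound 4 `CC1(/C=C/c2ccc(F)cc2)C=CC(=O)O1`, which differs from compound 3 as follows: fluoro in place of trifluoromethyl on an aromatic carbon. In words, this is fluoro in place of trifluoromethyl on an aromatic carbon.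

Among the compounds with values here, two measured steps bear on this change. Trifluoromethyl in place of hydrogen on an aromatic carbon gave a 6.1-fold lower number from compound 1 to compound 2 (0.78 log units; beyond the scatter) and a 5.0-fold lower number from compound 1 to compound 3 (0.70 log units; beyond the scatter), both modest. Within the data shown here, no measured compound carries fluoro, so its effect has not been seen directly. Compound 4 is expected to fall between compound 3 and compound 1, closer to compound 3, given a 5.0-fold lower number from compound 1 to compound 3 (0.70 log units; beyond the scatter).

The estimated step is a 1.9-fold higher number from compound 3 to compound 4 (0.28 log units; within the scatter), a small move toward a higher number. The estimated value for compound 4 is 65000 nM, with an expected range of 25000 nM to 160000 nM.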

Compound 4, concentration for total growth inhibition: 101000 nM
Estimate against measurement, compound 4: 1.6-fold (0.19 log units) below; the measured number falls inside the stated range.
By their numbers in this assay, from the lowest: compounds 2 and 3 (each within the scatter of the next); then compounds 4 and 1 (each within the scatter of the next).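

On this aromatic carbon, the position para to a group of 9 heavy atoms, fluoro cannot stand in for trifluoromethyl in this assay: the exchange gives a 3.0-fold higher number from compound 3 to compound 4 (0.47 log units; beyond the scatter). This is also the first direct view of fluoro against hydrogen, and it gives a 1.7-fold lower number from compound 1 to compound 4 (0.23 log units; within the scatter), so the single fluorine cannot be told apart from hydrogen here, whereas trifluoromethyl at the same place clearly can. No measurement shown explains why the two groups differ.

As far as these compounds go, it remains open whether a methoxy group, a chloro group or an amine at this position would track with trifluoromethyl or with fluoro. Also open, from the compounds shown here alone, is how fluoro would behave on the aromatic carbon that carries trifluoromethyl in compound 2.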